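This account rests on a few compounds, and the source may have more. Where it says the series, first, only, none or still open, it means among the compounds named here.

Measured compounds:
- compound 1, `CC1CCCCC1Oc1cccc2ccc(N)nc12`: 32 nM
- compound 2, `CCCOc1cccc2ccc(N)nc12`: 1100 nM
- compound 3, `CCCCOc1cccc2ccc(N)nc12`: 789 nM

In an assay on cells with melanin-concentrating hormone receptor 1 (Homo sapiens) as the target, read by radioligand binding (a higher number here means a weaker inhibitor, a lower number a stronger inhibitor), compound 1 gives the lowest number of the three, the strongest inhibitor here. Compound 3 stands nearest to it, with a number that is beyond the scatter of compound 1, and compound 2 stands furthest away, also beyond the scatter. Compound 4 is `Nc1ccc2cccc(OC3CCCCC3)c2n1`. It differs from compound 1 in one place: hydrogen in place of methyl on a saturated ring carbon. Among the measured compounds shown here, only one measured step bears on a change of this kind, and only in reverse: a 1.4-fold lower number from compound 2 to compound 3 (0.14 log units; within the scatter), where a methyl was added rather than removed, and on a chain rather than a ring. That step was within the scatter, so on this basis the loss of the methyl is expected to change the number in this assay little, perhaps a small move toward a higher number, and it cannot be said with confidence to go beyond the scatter. Compound 4 is therefore estimated to give 60 nM, with a range of 20 nM to 250 nM, an expected step of a 1.9-fold higher number from compound 1 to compound 4 (0.27 log units; within the scatter).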

Compound 4, half-maximal inhibitory concentration: 361 nM
Compound 4: the middle estimate sits 6.0-fold (0.78 log units) below what was measured; measured number above the stated range.
By their numbers in this assay, from the lowest: compound 1; then compound 4; then compounds 3 and 2 (each within the scatter of the next).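

In this assay, the methyl on the saturated ring carbon, next to the ring atom that bears a large group, matters far more than the earlier chain step suggested: removing it produces an 11-fold higher number from compound 1 to compound 4 (1.05 log units; beyond the scatter), a large change. The ring without the methyl still improves on the open chains, but only modestly, with a 2.2-fold lower number from compound 3 to compound 4 (0.34 log units; beyond the scatter) and a 3.0-fold lower number from compound 2 to compound 4 (0.48 log units; beyond the scatter), so the single methyl gives a larger step than replacing either chain with cyclohexyl. Nothing available here explains why one carbon has so much effect.

The compounds shown leave open whether an ethyl group or a hydroxyl group on the same ring carbon would match the methyl. They also leave open whether a methyl on a different carbon of the ring would give a comparable number.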